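Swapping a halogen on the aniline ring of a quinazoline-linker series

The compounds below may be only part of what the source reports. "The series", "measured", "known", "first", "only" and "open" are said of these compounds alone.

Measured so far, in a functional assay on A-431 cells (Homo sapiens) for antiproliferative activity, read by MTT assay, with a stated time of 72 h; on this read-out lower numbers stand for stronger inhibition and higher numbers for weaker inhibition:
- compound 1, `COc1cc2ncnc(Nc3ccc(F)c(Cl)c3)c2cc1OCCCCC(=O)Nc1ccc(S(N)(=O)=O)cc1`, gives 5020 nM
- compound 2, `COc1cc2ncnc(Nc3cccc(Cl)c3)c2cc1OCCCCC(=O)Nc1ccc(S(N)(=O)=O)cc1`, gives 30400 nM
- compound 3, `COc1cc2ncnc(Nc3ccc(Br)cc3)c2cc1OCCCCC(=O)Nc1ccc(S(N)(=O)=O)cc1`, gives 6570 nM

Compound 3 stands second highest of the three numbers. Its nearest neighbour is compound 1, and that gap, a 1.3-fold higher number from compound 1 to compound 3 (0.12 log units; within the scatter), is within the scatter, so the two cannot be ranked. Its furthest neighbour is compound 2, and the step of a 4.6-fold lower number from compound 2 to compound 3 (0.67 log units; beyond the scatter) is beyond the scatter, so compound 3 gives the stronger inhibition of those two.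

Compound 4, `COc1cc2ncnc(Nc3ccc(OC(F)(F)F)cc3)c2cc1OCCCCC(=O)Nc1ccc(S(N)(=O)=O)cc1`, differs from compound 3 only at the aromatic carbon of the six-membered aromatic ring of carbon only: trifluoromethoxy in place of bromo on an aromatic carbon. Among the compounds with values here, no measured compound carries a trifluoromethoxy group, so nothing tests this exact change. What the measured steps do show is that altering groups on this same ring moves the number by modest amounts: a 6.1-fold higher number from compound 1 to compound 2 (0.78 log units; beyond the scatter), a 4.6-fold lower number from compound 2 to compound 3 (0.67 log units; beyond the scatter), and the small 1.3-fold higher number from compound 1 to compound 3 (0.12 log units; within the scatter). A step of similar modest size, in either direction, is therefore expected for compound 4 in this assay, with no firm reason to favour a lower number. The estimate for compound 4 is 9000 nM, between 3000 nM and 27000 nM, meaning an expected step of a 1.4-fold higher number from compound 3 to compound 4 (0.14 log units; within the scatter).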

Compound 4, half-maximal inhibitory concentration: 22500 nM
Beside the measured number, compound 4's estimate is 2.5-fold (0.40 log units) below it; the range from low to high includes it.
By their numbers in this assay, from the lowest: compounds 1 and 3 (each within the scatter of the next); then compounds 4 and 2 (each within the scatter of the next).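

In this assay, the exchange of bromo for trifluoromethoxy on this aromatic carbon, para to a large group, is not a silent one: the step is a 3.4-fold higher number from compound 3 to compound 4 (0.53 log units; beyond the scatter) and it shows that the read-out depends on which of these two groups the carbon carries. The step of a 1.4-fold lower number from compound 2 to compound 4 (0.13 log units; within the scatter) leaves that pair unranked, while the step of a 4.5-fold higher number from compound 1 to compound 4 (0.65 log units; beyond the scatter) puts the new compound on the side of weaker inhibition. Nothing available here explains why the trifluoromethoxy group gives this result.

Within the data shown here, with only two groups compared alone at this position, a single step cannot show a trend. As far as these compounds go, it remains open how a methoxy group, an amine or a carboxylic acid on the same carbon would read out, and whether a longer chain would alter the effect of this swap.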